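The compounds below may be only part of what the source reports. "The series", "measured", "known", "first", "only" and "open" are said of these compounds alone.

Compound 1 `Cc1ccc(-n2cc(COc3cccc(NC(=O)Nc4ccc(Cl)c(C(F)(F)F)c4)c3)nn2)cc1` gives 5430 nM in a functional assay on HepG2 cells (Homo sapiens) for inhibition, read by MTT assay, with a stated time of 72 h (on this read-out higher numbers stand for weaker inhibition and lower numbers for stronger inhibition), the highest of the three numbers measured. Compound 2 `N#Cc1ccc(-n2cc(COc3cccc(NC(=O)Nc4ccc(Cl)c(C(F)(F)F)c4)c3)nn2)cc1` gives 2980 nM in this assay, and compound 3 `O=C(Nc1cccc(OCc2cn(-c3cccc(Cl)c3)nn2)c1)Nc1ccc(Cl)c(C(F)(F)F)c1` gives 2020 nM. The two measured steps away from compound 1 are a 1.8-fold lower number from compound 1 to compound 2 (0.26 log units; within the scatter) and a 2.7-fold lower number from compound 1 to compound 3 (0.43 log units; beyond the scatter); both replace or alter the aryl group on the ring nitrogen, and both move the number downward by a small amount. Compound 4 `COc1ccccc1-n1cc(COc2cccc(NC(=O)Nc3ccc(Cl)c(C(F)(F)F)c3)c2)nn1` carries the change (2-methoxyphenyl in place of 4-methylphenyl on an aromatic nitrogen). Neither measured step uses a 2-methoxyphenyl, so the bearing is indirect; a small lowering, or none beyond the scatter, is expected, with the estimated step being a 1.4-fold lower number from compound 1 to compound 4 (0.13 log units; within the scatter). Compound 4 is therefore estimated at 4000 nM, in the range 1800 nM to 9000 nM.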

Compound 4, half-maximal inhibitory concentration: 11300 nM
The estimate for compound 4 lay 2.8-fold (0.45 log units) below the measured number; measured number above the stated range.
By their numbers in this assay, from the lowest: compounds 3, 2 and 1 (each within the scatter of the next, the first and the last beyond it); then compound 4.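

Compound 4 shows that a change of aryl group on the aromatic nitrogen can also raise the number, with a 2.1-fold higher number from compound 1 to compound 4 (0.32 log units; beyond the scatter), whereas both earlier steps from compound 1 lowered it. The number for compound 4 is also higher than those of the other two compounds, with a 3.8-fold higher number from compound 2 to compound 4 (0.58 log units; beyond the scatter) and a 5.6-fold higher number from compound 3 to compound 4 (0.75 log units; beyond the scatter). No measurement available here accounts for this rise. The compounds shown do not separate the effect of the methoxy group from that of its place on the phenyl ring, and they leave open how a 4-methoxyphenyl or a 2-methylphenyl group on this nitrogen would read.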